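Methyl in Place of Trifluoromethyl: Expected Cytotoxicity

The source may hold more compounds than are shown below. What is called first, only, known or untested is meant among the compounds shown, and "the series" means these compounds.

Of the compounds shown here, two of a shared core have been tested in a functional assay on cells (Homo sapiens) for cytotoxicity; a higher number here means that more compound is tolerated, a lower number that less compound is tolerated. Compound 1 `O=C1N(CCCCCCCOc2ccc(Cl)cc2)CCN1c1cccnc1` reaches only a limit of the assay, > 25000 nM. Compound 2 `O=C1N(CCCCCCOc2ccc(C(F)(F)F)cc2)CCN1c1cccnc1` likewise gives no number but a limit in this assay, > 25000 nM. Both measured values therefore sit at the same limit, (the limit of > 25000 nM in this assay, at which 2 of the 2 values shown sit), so no difference between compound 1 and compound 2 is resolved and neither shows toxicity within the tested range. Compound 3 `Cc1ccc(OCCCCCCN2CCN(c3cccnc3)C2=O)cc1` has not yet been measured in this assay. It differs from compound 2 by methyl in place of trifluoromethyl on an aromatic carbon. The step from compound 2 to compound 3 is expected to be none beyond the scatter in this assay, a step that the limit leaves unreadable from compound 2 to compound 3, most probably ending at a limit once more. For compound 3 a value of 30000 nM is estimated, within 15000 nM to 60000 nM.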

Compound 3, half-maximal cytotoxic concentration: > 25000 nM
Compound 3: only a limit was reported; the forecaster's own chance of this, stated with the estimate: 85%; the middle value lies beyond the limit too.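

In this assay compound 3 reaches only a limit, > 25000 nM. The steps to compound 3 from compound 1 and compound 2 therefore cannot be read: the limit of > 25000 nM in this assay, at which 3 of the 3 values shown sit.

The compounds shown leave open whether methyl, trifluoromethyl or the other change makes any difference to cytotoxicity, since none gives a number.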